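Seven-Carbon Alkenyl Chain in Place of Isopropyl

This account rests on a few compounds, and the source may have more. Where it says the series, first, only, none or still open, it means among the compounds named here.

Among the compounds with values here, in an ADME assay on J774 cells (Mus musculus) for cytotoxicity (on this read-out lower numbers stand for an effect already at smaller amounts and higher numbers for an effect only at larger amounts of compound), compound 3 `COc1cc2[nH]c(C)c(C(C)C)c(=O)c2cc1Cl` gives 21700 nM, the only plain number among the three measured compounds. Compound 1 `CCCCCCCc1c(C)[nH]c2cc(OC)c(Cl)cc2c1=O` reaches only the limit of > 37100 nM. Compound 2 `COc1cc2[nH]c(C)c(C3CCCCC3)c(=O)c2cc1Cl` likewise stops at the limit of > 32700 nM. The change to compound 4 `C=C(CCCCC)c1c(C)[nH]c2cc(OC)c(Cl)cc2c1=O` is a group of 7 heavy atoms (7 carbon; no ring) in place of a group of 3 heavy atoms (3 carbon; no ring), on an aromatic carbon. Two measured steps run the opposite way: an at least 1.7-fold lower number from compound 1 to compound 3 (0.23 log units; that floor lies within the scatter) and an at least 1.5-fold lower number from compound 2 to compound 3 (0.17 log units; that floor lies within the scatter), each floor lying within the scatter. The entering group of compound 4 carries 7 carbon atoms, close to the heptyl of compound 1. Compound 4 is therefore expected to move back toward the limits, giving the estimated step of a 1.6-fold higher number from compound 3 to compound 4 (0.21 log units; within the scatter). Compound 4 is expected at 35000 nM, between 15000 nM and 80000 nM, with a fair chance that this assay again reports only a limit.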

Compound 4, half-maximal effective concentration: 18900 nM
Beside the measured number, compound 4's estimate is 1.9-fold (0.27 log units) above it; low and high end bracket the measured number.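

In this assay, the step is a 1.1-fold lower number from compound 3 to compound 4 (0.06 log units; within the scatter), so at this position the group of 7 carbon atoms with its double bond cannot be told apart from isopropyl. Against the two larger groups, the steps are an at least 1.7-fold lower number from compound 2 to compound 4 (0.23 log units; that floor lies within the scatter) and an at least 1.9-fold lower number from compound 1 to compound 4 (0.29 log units; that floor lies within the scatter), so neither floor shows a real change. Compound 4 gives a plain number where compound 1, whose group has the same carbon count, has only a limit: the limit of > 37100 nM in this assay, at which 1 of the 4 values shown sits.

From the compounds shown here alone, whether compound 1 truly differs from compound 4 stays open. So does what a chain ending in an amine would do at this position.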